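From trifluoromethyl to iodo on the shared core

The source may hold more compounds than are shown below. What is called first, only, known or untested is meant among the compounds shown, and "the series" means these compounds.

In a physicochemical assay for lipophilicity (a higher number here means a more lipophilic compound, a lower number a more polar compound), compound 1 (`Cc1ccccc1C1=NC(c2ccccc2)CO1`) gives 3.68 and compound 2 (`FC(F)(F)c1ccccc1C1=NC(c2ccccc2)CO1`) gives 3.71, so compound 2 stands level with compound 1 within the scatter. Compound 3 (`Ic1ccccc1C1=NC(c2ccccc2)CO1`) is still unmeasured and differs from compound 2 as follows: iodo in place of trifluoromethyl on an aromatic carbon. Among the measured compounds shown here, the only measured step that bears on this swap is a number 0.03 log units higher from compound 1 to compound 2 (within the scatter), where trifluoromethyl replaced methyl on an aromatic carbon. On that evidence, no step beyond the scatter is expected in this assay. The expected step is a number 0.06 log units lower from compound 2 to compound 3 (within the scatter). For compound 3 the estimated value is 3.65, with an expected range from 3.3 to 4.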

Compound 3, partition coefficient: 3.86
For compound 3 the middle estimate is 0.21 log units below the measured one, and the stated range covers the measured number.
By their numbers in this assay, from the lowest: compounds 1, 2 and 3 (each within the scatter of the next).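

In this assay, exchanging the four heavy atoms of trifluoromethyl for the single iodine atom on this aromatic carbon, ortho to a large group, gives a number 0.15 log units higher from compound 2 to compound 3 (within the scatter). Against methyl, the iodo group gives a number 0.18 log units higher from compound 1 to compound 3 (within the scatter). Methyl, trifluoromethyl and iodo therefore all stand level at this position, despite the difference in heavy atoms between the last two. Nothing available explains these steps. As far as these compounds go, whether an amine or a carboxylic acid on this aromatic carbon would give a step beyond the scatter remains open.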